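Aryl nitrogen substituent series: chloro to diethylamino

This account rests on a few compounds, and the source may have more. Where it says the series, first, only, none or still open, it means among the compounds named here.

Compound 3 `O=C1C2=C(C(=O)c3ncccc31)C1(CS2)NC(=O)N(c2ccc(Cl)cc2)C1=O` gives 590 nM in a functional assay on XF498 cells (Homo sapiens) for antiproliferative activity, read by MTT assay, with a stated time of 96 h (on this read-out higher numbers stand for weaker inhibition and lower numbers for stronger inhibition), the lowest of the three numbers measured. Compound 1 `COc1ccc(N2C(=O)NC3(CSC4=C3C(=O)c3ncccc3C4=O)C2=O)cc1` stands nearest with 650 nM, a gap within the scatter, as a 1.1-fold lower number from compound 1 to compound 3 (0.04 log units; within the scatter) shows. Compound 2 `O=C1NC(=O)C2(CSC3=C2C(=O)c2ncccc2C3=O)N1` lies furthest with 3120 nM; the step of a 5.3-fold lower number from compound 2 to compound 3 (0.72 log units; beyond the scatter) is beyond the scatter, and so is a 4.8-fold higher number from compound 1 to compound 2 (0.68 log units; beyond the scatter), which together point to the aryl group on the ring nitrogen as the part that carries weight here.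

Compound 4 `CCN(CC)c1ccc(N2C(=O)NC3(CSC4=C3C(=O)c3ncccc3C4=O)C2=O)cc1` differs from compound 3 in one place: diethylamino in place of chloro on an aromatic carbon. The step that bears on this exchange is a 1.1-fold lower number from compound 1 to compound 3 (0.04 log units; within the scatter), where swapping one substituent for another on the same aromatic carbon of a six-membered aromatic ring of carbon only produced no step beyond the scatter. Within the data shown here, no measured step shows an amino-type substituent at this position, so the bearing is indirect.

On this basis compound 4 is expected near compound 3, with an expected step of a 1.1-fold higher number from compound 3 to compound 4 (0.04 log units; within the scatter) that need not exceed the scatter. Compound 4 is estimated at 650 nM, within the range 250 nM to 1700 nM.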

Compound 4, half-maximal inhibitory concentration: 730 nM
Estimate against measurement, compound 4: 1.1-fold (0.05 log units) below; low and high end bracket the measured number.
By their numbers in this assay, from the lowest: compounds 3, 1 and 4 (each within the scatter of the next); then compound 2.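

In this assay, among these compounds, the substituent on the aromatic carbon para to a large group takes a much bigger group than the earlier compounds showed: diethylamino brings 5 heavy atoms where chloro had 1, and a 1.2-fold higher number from compound 3 to compound 4 (0.09 log units; within the scatter) is the whole effect of that exchange. Against methoxy the picture is the same, with a 1.1-fold higher number from compound 1 to compound 4 (0.05 log units; within the scatter) as the result, so chloro, methoxy and diethylamino, an amino-type group now included, cannot be told apart at this position on these numbers. No measurement at hand accounts for this flat response.

Open, on these data alone, is whether a carboxylic acid or a primary amine on this same carbon would also stay within the scatter. Also open, as far as these compounds go, is whether a benzyl group or a longer alkyl chain could stand in for the aryl group on the ring nitrogen.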